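This account rests on a few compounds, and the source may have more. Where it says the series, first, only, none or still open, it means among the compounds named here.

Two compounds of the series carry numbers in an assay on HEK293 cells for inhibition of neurogenic locus notch homolog protein 1 (Homo sapiens), read by a luciferase reporter and resazurin assay, with a stated time of 16 h; a lower number here means a stronger inhibitor, a higher number a weaker inhibitor. Compound 1 `CC1=C(C(=O)OC2CCCCC2)C(c2cccc(Br)c2)C2=C(CC(C)(C)CC2=O)N1` gives 4150 nM. Compound 2 `CC1=C(C(=O)OCC2CCN(C(=O)OC(C)(C)C)CC2)C(c2cccc([N+](=O)[O-])c2)C2=C(CC(C)(C)CC2=O)N1` gives only a limit, > 10000 nM, which is not a measured number. Compound 2 therefore stands at the weak end of what has been seen, with its true value unknown beyond that bound. The two values agree in that neither compound is a strong inhibitor; the pair differs in more than one place, and nothing further is drawn from it. Compound 3 `CC1=C(C(=O)OCC2CCN(C(=O)OC(C)(C)C)CC2)C(c2cccc(C#N)c2)C2=C(CC(C)(C)CC2=O)N1` follows from compound 2 by a single change: cyano in place of nitro on an aromatic carbon. Going by the values given here, no measured step of this kind exists, and the size of the step is not known from data. Since compound 2 sits at the limit of > 10000 nM in this assay, at which 1 of the 2 values shown sits, a movement in this assay of no more than the scatter would leave compound 3 at or beyond the same bound. The expected step from compound 2 to compound 3 is estimated as a step that the limit leaves unreadable from compound 2 to compound 3, none beyond the scatter. Compound 3 is expected at 15000 nM, in a range from 4000 nM to 50000 nM, most likely reported again only as a limit.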

Compound 3, half-maximal inhibitory concentration: 220 nM
The estimate for compound 3 lay 68-fold (1.83 log units) above the measured number, outside the stated range (below it).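

In this assay, going by these compounds alone, the change from 3-nitrophenyl to 3-cyanophenyl, with the ester side chain and the core held constant, gives an at least 45-fold lower number from compound 2 to compound 3 (1.65 log units; beyond the scatter) and is the first single-place comparison. The group on this aromatic carbon, meta to a large group, therefore strongly affects the reading in this pair, and the ester side chain shared by compound 2 and compound 3 does not by itself keep a compound at the weak end of the assay. The step gives only a minimum size, because compound 2 is reported as a limit and not as a number: the limit of > 10000 nM in this assay, at which 1 of the 3 values shown sits.

The compounds shown do not tell whether the nitrile is specifically favoured at this place or whether the nitro group is specifically disfavoured, and a primary amine, a carboxylic acid or a methoxy group there would help separate these readings. Compound 1 differs from compound 3 in more than one place, so the contributions of its bromine and cyclohexyl ester cannot be separated from those of the nitrile and the ester side chain.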